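A few compounds are considered here, and "the series" means these few. Any claim that something is new, unique, unknown or untested is made for them only; others in the source may bear on it.

Compound 1 `C[C@H](CO)Nc1nc(C(=O)NCc2ccc(F)cc2)c(O)c2ncccc12`: a limit of the assay, > 20000 nM

Compound 2 `N[C@H]1CC[C@H](Nc2c(C(=O)NCc3ccc(F)cc3)nc(Br)c3cccnc23)CC1`: 6000 nM

Compound 3 `O=C(NCCCNc1c(C(=O)NCc2ccc(F)cc2)nc(Br)c2cccnc12)c1ccccc1`: a limit of the assay, > 20000 nM

All three compounds were tested in a functional assay on MDA-MB-435 cells (Homo sapiens) for cytotoxicity, read by MTT assay, with a stated time of 72 h; on this read-out lower numbers stand for stronger inhibition and higher numbers for weaker inhibition. Compound 3 returns only a limit of the assay, > 20000 nM, and so no number of its own. the limit of > 20000 nM in this assay, at which 2 of the 3 values shown sit, shows that compound 3 is one of two compounds whose potency does not reach the range the assay resolves. Among the compounds with values here, compound 2 gives 6000 nM, the one value in this set that is a number.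

Compound 4 `CN(C)CCCNc1c(C(=O)NCc2ccc(F)cc2)nc(Br)c2cccnc12` is the next compound to be measured in this assay. It differs from compound 3 in a single place:

dimethylamino in place of benzamido on a saturated chain carbon, three bonds along the chain from a nitrogen on an aromatic ring

No pair of measured compounds shares this change, so its size in this assay cannot be read from the data shown, and compound 3 itself offers only a limit as a starting point. Since compound 2 gives 6000 nM, a number within the range the assay resolves, a measurable value for compound 4 is thought possible but far from certain; the other two compounds give no number of their own. Compound 4 is expected to give about 8000 nM. Compound 4 is estimated to fall between 2000 nM and 20000 nM. The expected step is an at least 2.5-fold lower number from compound 3 to compound 4 (0.39 log units; beyond the scatter), that is, a move from the limit toward stronger inhibition, with a real chance that the assay again reports only a limit.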

Compound 4, half-maximal inhibitory concentration: 7000 nM
Estimate against measurement, compound 4: 1.1-fold (0.06 log units) above; the range from low to high includes it.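

In this assay, within the data shown here, replacing benzamido with dimethylamino on a saturated chain carbon, three bonds along the chain from a nitrogen on an aromatic ring, gives an at least 2.8-fold lower number from compound 3 to compound 4 (0.45 log units; beyond the scatter), which shows that the read-out at this place responds to the group on the chain, something the earlier compounds could not show. With a 1.2-fold higher number from compound 2 to compound 4 (0.07 log units; within the scatter), the 3-(dimethylamino)propyl and 4-aminocyclohexyl groups on a nitrogen on an aromatic ring cannot be told apart in this assay, so two quite different substituents carrying an amine reach the same level. Compound 3 stands only as a limit of the assay, so the full size of the step from benzamido to dimethylamino stays unknown: the limit of > 20000 nM in this assay, at which 2 of the 4 values shown sit.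

The compounds shown leave open whether the step depends on the dimethylamino group itself or only on the departure of benzamido, a question that a primary amine, a morpholine or a simple hydroxyl at the same place would address. They also leave open whether a longer or shorter chain carrying the dimethylamino group would change the value beyond the usual scatter.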